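A few compounds are considered here, and "the series" means these few. Any claim that something is new, unique, unknown or untested is made for them only; others in the source may bear on it.

Compound 2 `COc1ccc2c(c1)/C(=C1/Nc3ccccc3/C1=N\O)C(=O)N2Cc1ccc(/C=C/C(=O)NO)cc1` gives 50 nM in a functional assay on NCI-H23 cells (Homo sapiens) for cytotoxicity, read by colorimetric assay (on this read-out lower numbers stand for stronger inhibition and higher numbers for weaker inhibition), and stands highest of the two numbers measured there. Among the compounds with values here, its only neighbour, compound 1 `O=C(/C=C/c1ccc(CN2C(=O)/C(=C3\Nc4ccccc4\C3=N/O)c3cc(Cl)ccc32)cc1)NO`, gives 7 nM in this assay, and the one measured step, a 7.1-fold higher number from compound 1 to compound 2 (0.85 log units; beyond the scatter), replaces chloro with methoxy on an aromatic carbon. Compound 3 `O=C(/C=C/c1ccc(CN2C(=O)/C(=C3\Nc4ccccc4\C3=N/O)c3ccccc32)cc1)NO` is the unmeasured member: hydrogen in place of methoxy on an aromatic carbon. Within the data shown here, the step from compound 1 to compound 2 bears on this change only in part, since it shows that the group at this aromatic carbon matters, with methoxy giving the weaker number, but no measured compound carries hydrogen there. Compound 3 is therefore expected to land between the two measured numbers, and the step of a 2.5-fold lower number from compound 2 to compound 3 (0.40 log units; beyond the scatter) is estimated as a moderate move toward stronger inhibition. Compound 3 is estimated at 20 nM, within a range from 7 nM to 60 nM in this assay.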

Compound 3, half-maximal inhibitory concentration: 9 nM
The estimate for compound 3 lay 2.2-fold (0.35 log units) above the measured number; measured number inside the range.
By their numbers in this assay, from the lowest: compounds 1 and 3 (each within the scatter of the next); then compound 2.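

With hydrogen on this aromatic carbon, this assay now has a reference point for the position: hydrogen in place of methoxy gives a 5.6-fold lower number from compound 2 to compound 3 (0.74 log units; beyond the scatter), while hydrogen in place of chloro gives a 1.3-fold higher number from compound 1 to compound 3 (0.11 log units; within the scatter). The earlier gap between chloro and methoxy therefore reflects methoxy standing apart from both other compounds, as chloro and hydrogen cannot be told apart here. Nothing available gives a reason for the methoxy result.

Going by these compounds, it remains open whether other groups at this carbon, such as fluoro, methyl, hydroxy or an amine, would stay with chloro and hydrogen or go with methoxy. On these data alone, it is also open whether the same holds for these groups on other aromatic carbons of the shared core.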